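The source may hold more compounds than are shown below. What is called first, only, known or untested is meant among the compounds shown, and "the series" means these compounds.

Three compounds built on a shared core were run in a functional assay on HT-29 cells (Homo sapiens) for inhibition, read by MTT assay, with a stated time of 72 h; on this read-out higher numbers stand for weaker inhibition and lower numbers for stronger inhibition. Compound 1 `COc1cc2c(Oc3ccc(NC(=O)c4nn(-c5ccccc5C)c(=O)cc4C)cc3F)ccnc2cc1OCCCN1CCC(C)CC1` gives 2810 nM in this assay. Compound 2 `COc1cc2c(Oc3ccc(NC(=O)c4nn(-c5ccccc5C)c(=O)cc4C)cc3F)ccnc2cc1OCCCN1CCN(C)CC1` carries 4-methylpiperazin-1-yl in place of 4-methylpiperidin-1-yl on a saturated chain carbon, three bonds along the chain from an oxygen on an aromatic ring and gives 3790 nM in this assay; the step of a 1.3-fold higher number from compound 1 to compound 2 (0.13 log units; within the scatter) lies within the scatter, so the two numbers are not told apart. Compound 3 `COc1cc2c(Oc3ccc(NC(=O)c4nn(-c5ccc(Cl)cc5)c(=O)cc4C)cc3F)ccnc2cc1OCCCN1CCC(C)CC1` differs from compound 1 by 4-chlorophenyl in place of 2-methylphenyl on an aromatic nitrogen, which is also how the core of compound 3 and compound 4 differs from the core of compound 1 and compound 2; compound 3 gives 180 nM in this assay, and the step of a 16-fold lower number from compound 1 to compound 3 (1.19 log units; beyond the scatter) is beyond the scatter. Compound 3 has the lowest number of the three, and its steps to compound 1 and to compound 2 are both beyond the scatter.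

Compound 4 `COc1cc2c(Oc3ccc(NC(=O)c4nn(-c5ccc(Cl)cc5)c(=O)cc4C)cc3F)ccnc2cc1OCCCN1CCN(C)CC1` has not yet been measured. It differs from compound 3 by 4-methylpiperazin-1-yl in place of 4-methylpiperidin-1-yl on a saturated chain carbon, three bonds along the chain from an oxygen on an aromatic ring. For the measured compounds named here, this is the same change as the one from compound 1 to compound 2, made at the same place; among the four compounds it occurs twice. For compound 4 a step of a 1.3-fold higher number from compound 3 to compound 4 (0.11 log units; within the scatter) is expected, set beside the earlier step, because the same change once gave a 1.3-fold higher number from compound 1 to compound 2 (0.13 log units; within the scatter) and that step stayed within the scatter. The expectation rests on that single earlier pair and on the value of compound 3, 180 nM. Compound 4 is therefore expected to give about 230 nM in this assay, with the likely range from 110 nM to 500 nM.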

Compound 4, half-maximal inhibitory concentration: 320 nM
Estimate against measurement, compound 4: 1.4-fold (0.14 log units) below, and the stated range covers the measured number.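

In this assay the step of a 1.8-fold higher number from compound 3 to compound 4 (0.25 log units; within the scatter) leaves the 4-methylpiperazin-1-yl and 4-methylpiperidin-1-yl compounds on the core of compound 3 not told apart, which matches what the same change did on the core of compound 1: the same change on two cores in this assay, a 1.3-fold higher number (0.13 log units; within the scatter) from compound 1 to compound 2 and a 1.8-fold higher number (0.25 log units; within the scatter) from compound 3 to compound 4, 1.3-fold (0.12 log units) apart, within the scatter of two such steps. The change on the aromatic nitrogen, 4-chlorophenyl in place of 2-methylphenyl, also carries over, with the step of a 12-fold lower number from compound 2 to compound 4 (1.07 log units; beyond the scatter) beyond the scatter and not told apart in size from the earlier one: the same change on two cores in this assay, a 16-fold lower number (1.19 log units; beyond the scatter) from compound 1 to compound 3 and a 12-fold lower number (1.07 log units; beyond the scatter) from compound 2 to compound 4, 1.3-fold (0.12 log units) apart, within the scatter of two such steps. Within these four compounds, then, each change gives the same result whichever form the other place takes, but this rests on two pairs of compounds in a single cell assay and does not show that the agreement would hold on any other core.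

The compounds shown leave open whether a morpholine or a dimethylamino group at the end of the chain, or a shorter chain such as 2-(4-methylpiperazin-1-yl)ethyl, would also leave the number unmoved. They also leave open how a plain phenyl or a fluorophenyl on the aromatic nitrogen would read, and so whether the chlorine, the methyl group or both account for the large step.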